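The compounds below may be only part of what the source reports. "The series", "measured", "known", "first", "only" and "open" are said of these compounds alone.

Three compounds share one core, and all three have been tested in a functional assay on SK-OV-3 cells (Homo sapiens) for inhibition, read by sulforhodamine B assay, with a stated time of 72 h; a lower number here means a stronger inhibitor of growth, a higher number a weaker inhibitor of growth. Compound 1 `CC(C)(C)OC(=O)NCCCCCNC1=Nc2ccccc2C(CC(=O)NCc2ccccc2)N1c1ccccc1` gives 7180 nM. Compound 2 `COC(=O)CC1c2ccccc2N=C(NCCCCCNC(=O)OC(C)(C)C)N1c1ccc(-c2ccccc2)cc1` gives 4610 nM. Compound 3 `COC(=O)CC1c2ccccc2N=C(Nc2ccc(-c3ccccc3)cc2)N1CCCCCN` gives 3990 nM. Among these three numbers compound 2 sits second highest, but the gap to compound 3, its nearest neighbour, and the gap to compound 1, its furthest, both lie within the scatter of repeated measurements, so the three results cannot be told apart with confidence.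

The next compound, compound 4 `CC(C)(C)OC(=O)NCCCCCNC1=Nc2ccccc2C(CC(=O)NCc2ccccc2)N1c1ccc(-c2ccccc2)cc1`, is built from compound 2 by a single change: benzylamino in place of methoxy on a carbonyl carbon. The ester is thus turned into an amide carrying a benzyl group, while everything else in compound 2 is kept.

For the measured compounds named here, no pair of measured compounds differs in just this way, so there is no direct precedent for the size of the step. Since all three measured numbers fall within the scatter of one another, the expectation is that the step from compound 2 to compound 4 will also be small, a 1.2-fold higher number from compound 2 to compound 4 (0.08 log units; within the scatter), with no clear direction beyond the scatter. On that basis compound 4 is expected to give about 5500 nM in this assay, somewhere between 2500 nM and 12000 nM.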

Compound 4, concentration for 50% growth inhibition: 1610 nM
Compound 4: middle estimate off by 3.4-fold (0.53 log units), on the high side; measured number outside the range, below it.
By their numbers in this assay, from the lowest: compound 4; then compounds 3, 2 and 1 (each within the scatter of the next).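

In this assay, benzylamino in place of methoxy on the carbonyl carbon gives a 2.9-fold lower number from compound 2 to compound 4 (0.46 log units; beyond the scatter) and so moves the number beyond the scatter, which none of the comparisons among the first three compounds could do; what sits on this carbonyl carbon therefore matters for growth inhibition in these cells. Compound 4 also completes a second one-place pair, where phenyl in place of hydrogen on an aromatic carbon gives a 4.5-fold lower number from compound 1 to compound 4 (0.65 log units; beyond the scatter) and is likewise beyond the scatter, so the lower number in compound 4 depends on both the benzylamino group and this phenyl. Nothing shown here explains either step.

The compounds shown leave open whether the amide link or the benzyl ring carries the effect, a question that a methylamino or phenethylamino group on the same carbonyl carbon could help to settle. As far as these compounds go, it also remains open how a carboxylic acid at this carbon would read, and whether a methyl group in place of the added phenyl would keep the number this low.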